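Methyl and Amide Methylation Replace a Methoxybenzyl Amide

The source may report more compounds than this note shows. Statements on the series, on what has been measured and on what is new or still open speak of the compounds shown alone.

Compound 3 `COc1cccc(CNC(=O)c2nn(-c3ccc(F)cc3)c(OC[C@@H](O)C[C@@H](O)CC(=O)O)c2C(C)C)c1` gives 8750 nM in a functional assay on L6 cells (Rattus norvegicus) for inhibition (on this read-out lower numbers stand for stronger inhibition and higher numbers for weaker inhibition), the highest of the three numbers: compound 1 `CC(C)c1c(C(=O)NCc2cccc(F)c2F)nn(-c2ccc(F)cc2)c1OC[C@@H](O)C[C@@H](O)CC(=O)O` gives 120 nM and compound 2 `Cc1cccc(CNC(=O)c2nn(-c3ccc(F)cc3)c(OC[C@@H](O)C[C@@H](O)CC(=O)O)c2C(C)C)c1` gives 280 nM. Compound 4 `Cc1cccc(CN(C)C(=O)c2nn(-c3ccc(F)cc3)c(OC[C@@H](O)C[C@@H](O)CC(=O)O)c2C(C)C)c1` carries methyl(3-methylbenzyl)amino in place of (3-methoxybenzyl)amino on a carbonyl carbon. Going by the values given here, two measured steps bear on this: a 31-fold higher number from compound 2 to compound 3 (1.49 log units; beyond the scatter) and a 73-fold higher number from compound 1 to compound 3 (1.86 log units; beyond the scatter), so returning methyl in place of methoxy should largely reverse the first of these. Among the compounds with values here, no measured pair shows an amide nitrogen losing its hydrogen for a methyl, and this part of the change is unanchored. A large step to a lower number is therefore expected, tempered by that uncertainty; compound 4 is estimated at 700 nM, between 150 nM and 3500 nM, a step of a 13-fold lower number from compound 3 to compound 4 (1.10 log units; beyond the scatter).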

Compound 4, half-maximal inhibitory concentration: 18500 nM
Compound 4: the middle estimate sits 26-fold (1.42 log units) below what was measured; measured number above the stated range.
By their numbers in this assay, from the lowest: compound 1; then compound 2; then compound 3; then compound 4.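

In this assay, going by these compounds alone, the amide hydrogen proves to matter at this position: methyl in place of hydrogen on the amide-type nitrogen, the only change, gives a 66-fold higher number from compound 2 to compound 4 (1.82 log units; beyond the scatter). The benefit of methyl over methoxy on the aromatic carbon does not survive this change, with a 2.1-fold higher number from compound 3 to compound 4 (0.33 log units; beyond the scatter), and the distance from the difluorinated amide widens to a 150-fold higher number from compound 1 to compound 4 (2.19 log units; beyond the scatter). Nothing available explains this loss. As far as these compounds go, it remains open whether any group on that nitrogen, such as ethyl, would behave like methyl, and whether the same loss would appear with the 2,3-difluorobenzyl group.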